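Phenyl in Place of Methyl on Two Related Cores

A few compounds are considered here, and "the series" means these few. Any claim that something is new, unique, unknown or untested is made for them only; others in the source may bear on it.

Measured in a functional assay on SK-N-SH cells (Homo sapiens) for antiproliferative activity, read by MTT assay, with a stated time of 48 h; on this read-out higher numbers stand for weaker inhibition and lower numbers for stronger inhibition:
compound 1 `Cc1oc2c3c(ccc2c(=O)c1C)OC[C@H]1[C@@H]3C2=C(CC(C)(C)CC2=O)OC1(C)C`: > 100000 nM, a limit of the assay rather than a number.
compound 2 `Cc1oc2c3c(ccc2c(=O)c1-c1ccccc1)OC[C@H]1[C@@H]3C2=C(CC(C)(C)CC2=O)OC1(C)C`: > 100000 nM, also a limit of the assay.
compound 3 `Cc1nn(-c2ccccc2)c2c1[C@@H]1c3c(ccc4c(=O)c(C)c(C)oc34)OC[C@@H]1C(C)(C)O2`: 10600 nM.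

From compound 1 to compound 2 the change is phenyl in place of methyl on an aromatic carbon, and the step that the two limits leave unreadable from compound 1 to compound 2 cannot be read, since both values sit at the limit of > 100000 nM in this assay, at which 2 of the 3 values shown sit. How the core of compound 3 differs from the core of compound 1 is not broken down here. Compound 4 `Cc1nn(-c2ccccc2)c2c1[C@@H]1c3c(ccc4c(=O)c(-c5ccccc5)c(C)oc34)OC[C@@H]1C(C)(C)O2` carries the same change, (phenyl in place of methyl on an aromatic carbon), made on the core of compound 3. Among the measured compounds shown here, the one earlier example gives no readable size, so the expected step of a 1.4-fold higher number from compound 3 to compound 4 (0.15 log units; within the scatter) is set close to no change, resting on compound 3 with 10600 nM. Compound 4 is therefore estimated at 15000 nM, between 3000 nM and 100000 nM.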

Compound 4, half-maximal inhibitory concentration: > 100000 nM
Compound 4 ended at the assay's limit; the forecaster's own chance of this, stated with the estimate: 35%; at least 6.6-fold (0.82 log units) between middle value and limit.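

In this assay, phenyl in place of methyl on an aromatic carbon of the core of compound 3 gives an at least 9.4-fold higher number from compound 3 to compound 4 (0.97 log units; beyond the scatter), so on this core the change clearly weakens inhibition. From the compounds shown here alone, the value of compound 4, > 100000 nM, is a limit of the assay and not a number, so the full size of the step remains unknown. Whether the change acts alike on both cores cannot be told, since the step between the compounds on the other core cannot be read: the limit of > 100000 nM in this assay, at which 3 of the 4 values shown sit.

Among the compounds shown, only methyl and phenyl occupy this aromatic carbon. Going by these compounds, how an ethyl group, or an amine or carboxylic acid on the phenyl ring, would read on the core of compound 3 stays open.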